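Cyano to methoxy on the aryl group of compound 1

A few compounds are considered here, and "the series" means these few. Any claim that something is new, unique, unknown or untested is made for them only; others in the source may bear on it.

In a functional assay on HepG2 cells (Homo sapiens) for inhibition, read by MTT assay, with a stated time of 24 h (on this read-out lower numbers stand for stronger inhibition and higher numbers for weaker inhibition), compound 1 `CC1(C)[C@H]2CC[C@]1(C)N(Cc1cn(-c3ccc(C#N)cc3)nn1)C(=O)C2` gives 50 nM. Going by the values given here, the only other number in this assay belongs to compound 2 `CC1(C)[C@H]2CC[C@]1(C)N(Cc1cn(-c3ccccc3)nn1)C(=O)C2`, which gives 90 nM, and the two lie within the scatter of each other, as the step of a 1.8-fold higher number from compound 1 to compound 2 (0.26 log units; within the scatter) shows. Compound 3 `COc1ccc(-n2cc(CN3C(=O)C[C@@H]4CC[C@@]3(C)C4(C)C)nn2)cc1` carries the change (methoxy in place of cyano on an aromatic carbon). Among the compounds with values here, the one step that bears on it, the loss of the cyano, stayed within the scatter, so no step beyond the scatter is expected here either, with a 1.4-fold higher number from compound 1 to compound 3 (0.15 log units; within the scatter) as the expected outcome. Compound 3 is therefore estimated at 70 nM, in the range 25 nM to 200 nM.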

Compound 3, half-maximal inhibitory concentration: 100 nM
Compound 3: the middle estimate sits 1.4-fold (0.15 log units) below what was measured, within the range that was stated.
By their numbers in this assay, from the lowest: compounds 1, 2 and 3 (each within the scatter of the next).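

In this assay the aromatic carbon para to a large group now carries cyano, hydrogen or methoxy with no step beyond the scatter: a 2.0-fold higher number from compound 1 to compound 3 (0.30 log units; within the scatter) stands within it, and so does a 1.1-fold higher number from compound 2 to compound 3 (0.05 log units; within the scatter). Cyano and methoxy thus do not separate at this position, and neither separates from hydrogen. No measured evidence on these steps is available to explain this.

On these data alone, whether an amine, a carboxylic acid or a longer chain such as butoxy at this carbon would give a step beyond the scatter remains open. Also open, as far as these compounds go, is the effect of any group placed elsewhere on the aryl ring.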